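Bicyclic aryl groups and microsomal clearance in the series

The source may hold more compounds than are shown below. What is called first, only, known or untested is meant among the compounds shown, and "the series" means these compounds.

Measured compounds:
- compound 1 `COc1cc(C(O)(C(F)(F)F)C(F)(F)F)cnc1N1CCN(S(=O)(=O)c2ccc(N)nc2)CC1`: < 14 mL.min-1.g-1
- compound 2 `Nc1ccc(S(=O)(=O)N2CCN(c3ncc(C(O)(C(F)(F)F)C(F)(F)F)cc3-c3ccoc3)CC2)cn1`: < 14 mL.min-1.g-1
- compound 3 `Nc1ccc(S(=O)(=O)N2CCN(c3ncc(C(O)(C(F)(F)F)C(F)(F)F)cc3-c3ccc4scnc4c3)CC2)cn1`: 39 mL.min-1.g-1

In an ADME assay (liver) for metabolic stability, with Liver microsome (Homo sapiens) as the target, using microsomes and NADPH, with a stated time of 30 min, tested at 1 uM (on this read-out higher numbers stand for fast clearance and lower numbers for slow clearance), compound 1 gives < 14 mL.min-1.g-1, which is a limit of the assay rather than a number. Compound 2 gives < 14 mL.min-1.g-1, again a limit, so compound 2 sits at the floor of the read-out, (the limit of < 14 mL.min-1.g-1 in this assay, at which 2 of the 3 values shown sit). Compound 3 gives 39 mL.min-1.g-1. The step of an at least 2.7-fold higher number from compound 2 to compound 3 (0.44 log units; beyond the scatter) and the step of an at least 2.7-fold higher number from compound 1 to compound 3 (0.44 log units; beyond the scatter) both show that the 1,3-benzothiazol-5-yl group carries the series off that floor; the step that the two limits leave unreadable from compound 1 to compound 2 cannot be sized because both ends are limits.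

Compound 4 `Nc1ccc(S(=O)(=O)N2CCN(c3ncc(C(O)(C(F)(F)F)C(F)(F)F)cc3-c3cc4ccccc4[nH]3)CC2)cn1` differs from compound 2 by 1H-indol-2-yl in place of furan-3-yl on an aromatic carbon. The relevant measured step is an at least 2.7-fold higher number from compound 2 to compound 3 (0.44 log units; beyond the scatter), in which a second aromatic ring also entered at this carbon. An increase of comparable size is expected, an at least 2.1-fold higher number from compound 2 to compound 4 (0.33 log units; beyond the scatter), with the chance that compound 4 still returns only a limit. Compound 4 is estimated at 30 mL.min-1.g-1, in the range 10 mL.min-1.g-1 to 90 mL.min-1.g-1.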

Compound 4, intrinsic clearance in microsomes: < 14 mL.min-1.g-1
Compound 4 was reported as a limit; the forecaster's own chance of this, stated with the estimate: 30%; middle value at least 2.1-fold (0.33 log units) from the limit.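

A second aromatic ring at this carbon does not by itself lift the series off the floor of this assay: compound 4 carries the bicyclic 1H-indol-2-yl group and still returns only a limit. Between the two bicyclic groups there is an at least 2.7-fold lower number from compound 3 to compound 4 (0.44 log units; beyond the scatter), so the added ring alone does not account for the higher clearance of compound 3, and the identity of the group matters. Compound 3 is now the only compound shown that stands off the floor: the limit of < 14 mL.min-1.g-1 in this assay, at which 3 of the 4 values shown sit.

The steps joining compound 4 to compound 1 and to compound 2 run between two limits and cannot be read, so any order among these three compounds stays unknown. Also open, on these data alone, is how the read-out responds to an amine such as morpholine at this carbon, a group with no aromatic ring.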